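A few compounds are considered here, and "the series" means these few. Any claim that something is new, unique, unknown or untested is made for them only; others in the source may bear on it.

Compound 1 `COc1cc(/C=C/C(=O)NNC(=O)c2ccccc2)ccc1O`, compound 2 `O=C(/C=C/c1ccc(O)c(O)c1)NNC(=O)c1ccccc1` and compound 3 `COc1ccc(C(=O)NNC(=O)/C=C/c2ccc(O)c(O)c2)cc1` have each been tested in a functional assay on NCI-H1299 cells (Homo sapiens) for antiproliferative activity, read by MTT assay, with a stated time of 24 h; a lower number here means a stronger inhibitor, a higher number a weaker inhibitor. In this assay compound 1 gives 6160 nM, compound 2 gives 6770 nM and compound 3 gives 5420 nM. Compound 1 and compound 2 differ by hydrogen in place of methyl on an oxygen on an aromatic ring, a change that produced a 1.1-fold higher number from compound 1 to compound 2 (0.04 log units; within the scatter). Compound 2 and compound 3 differ by a methoxy entering, giving a 1.2-fold lower number from compound 2 to compound 3 (0.10 log units; within the scatter). Compound 4 `O=C(/C=C/c1ccc(O)c(O)c1)NNC(=O)c1ccc(O)cc1` has not yet been tested; it differs from compound 3 by hydrogen in place of methyl on an oxygen on an aromatic ring, the same change at a place described in the same words. The difference between the cores of compound 1 and compound 3 is not broken down here. Because the earlier change produced a 1.1-fold higher number from compound 1 to compound 2 (0.04 log units; within the scatter), the expected outcome is a 1.1-fold higher number from compound 3 to compound 4 (0.04 log units; within the scatter), a step of similar size. Compound 4 is estimated at 5900 nM, with a likely range from 3000 nM to 11000 nM.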

Compound 4, half-maximal inhibitory concentration: 4480 nM
For compound 4 the middle estimate is 1.3-fold (0.12 log units) above the measured one, within the range that was stated.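

Replacing methyl with hydrogen on an oxygen on an aromatic ring gave no step beyond the scatter on either core in this assay: the same change on two cores in this assay, a 1.1-fold higher number (0.04 log units; within the scatter) from compound 1 to compound 2 and a 1.2-fold lower number (0.08 log units; within the scatter) from compound 3 to compound 4, 1.3-fold (0.12 log units) apart, within the scatter of two such steps. The new result is a 1.2-fold lower number from compound 3 to compound 4 (0.08 log units; within the scatter), and the step that brings in a hydroxy group gives a 1.5-fold lower number from compound 2 to compound 4 (0.18 log units; within the scatter). The methoxy to hydroxy swap therefore behaves alike on these two cores, but steps this small show neither a real effect of the change nor that it would stay this small on any other core.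

Going by these compounds, whether an amine or a carboxylic acid on that aromatic ring would give a step beyond the scatter remains open. The same holds for a longer chain in place of the methyl on the oxygen.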